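Acetate to Mesylate on the Aryl Oxygen of Compound 3

The compounds below may be only part of what the source reports. "The series", "measured", "known", "first", "only" and "open" are said of these compounds alone.

The series shares one core carrying an amide and a cinnamate ester; the members differ on the benzyl ring. Compound 1 `COC(=O)/C=C/c1cccc(N(Cc2ccc(-c3c(OC)cccc3OC)cc2)C(=O)C2CCCCC2)c1` bears a dimethoxyphenyl substituent, and in an assay on isolated protein with Bile acid receptor (Homo sapiens) as the target (on this read-out higher numbers stand for an effect only at larger amounts of compound and lower numbers for an effect already at smaller amounts), compound 1 gives 77 nM. Compound 2 `COC(=O)/C=C/c1cccc(N(Cc2ccc(/C=C/C(=O)OC(C)(C)C)cc2OC)C(=O)C2CCCCC2)c1` instead carries a tert-butyl cinnamate and a methoxy group. In this assay compound 2 gives > 1000 nM, which is a limit of the assay and not a number. Compound 3 `COC(=O)/C=C/c1cccc(N(Cc2ccc(/C=C/C(=O)OC(C)(C)C)cc2OC(C)=O)C(=O)C2CCCCC2)c1` keeps that cinnamate and has acetyl in place of methyl on an oxygen on an aromatic ring. In this assay compound 3 gives > 1000 nM, again a limit. The step that the two limits leave unreadable from compound 2 to compound 3 is therefore unreadable, since both values sit at the limit of > 1000 nM in this assay, at which 2 of the 3 values shown sit.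

Compound 4 `COC(=O)/C=C/c1cccc(N(Cc2ccc(/C=C/C(=O)OC(C)(C)C)cc2OS(C)(=O)=O)C(=O)C2CCCCC2)c1` is the next change: methylsulfonyl in place of acetyl on an oxygen on an aromatic ring. Among the compounds with values here, no measured step bears directly on it; the only neighbouring step is unreadable. He therefore expects compound 4 to stay near the limit, with a step that the limit leaves unreadable from compound 3 to compound 4 of no readable size, and estimates for compound 4 a value of 3000 nM, between 800 nM and 20000 nM.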

Compound 4, half-maximal effective concentration: > 1000 nM
Compound 4: only a limit was reported; the forecaster's own chance of this, stated with the estimate: 80%; the middle value lies beyond the limit too.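

In this assay compound 4 gives > 1000 nM, again a limit of the assay and not a number. The steps to compound 4 from compound 2 and compound 3 therefore cannot be read: the limit of > 1000 nM in this assay, at which 3 of the 4 values shown sit. The compounds shown leave open whether methyl, acetyl and methylsulfonyl on that oxygen differ at all in this assay.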